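Swapping in pyridin-2-yl: will cells still tolerate it?

The compounds below may be only part of what the source reports. "The series", "measured", "known", "first", "only" and "open" are said of these compounds alone.

In an ADME assay on MDBK cells (Bos taurus) for cytotoxicity (a lower number here means that less compound is tolerated, a higher number that more compound is tolerated), compound 2 `CC(C)=CCn1ccc2nc(-c3ccccc3)nc-2c1` gives > 100000 nM, which is a limit of the assay and not a number. Compound 1 `Cc1ccccc1Cn1ccc2nc(-c3ccccc3)nc-2c1` gives > 100000 nM, also a limit. Among the measured compounds shown here, the only measured step is therefore a step that the two limits leave unreadable from compound 1 to compound 2, so it offers no size to carry forward. Compound 3 `c1ccc(-c2nc3ccn(Cc4ccccn4)cc-3n2)cc1` has pyridin-2-yl in place of 2-methylprop-1-en-1-yl on a saturated chain carbon bound to an aromatic nitrogen. Compound 1 already has 2-methylphenyl at that place, and the evidence for compounds 1 and 2 is the limit of > 100000 nM in this assay, at which 2 of the 2 values shown sit, so no step beyond the usual scatter is expected in this assay. The expected change is a number no higher from compound 2 to compound 3 (the limit leaves the size open), and this is only an estimate. For compound 3 the estimated value is 100000 nM, with an expected range from 50000 nM to 200000 nM, and a report of only a limit is likely.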

Compound 3, half-maximal cytotoxic concentration: > 100000 nM
Compound 3 ended at the assay's limit; the forecaster's own chance of this, stated with the estimate: 75%; the middle value lies on the limit itself.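

Compound 3, like compound 1 and compound 2, stops at a limit of the assay and not at a number, so no step among these three can be read: the limit of > 100000 nM in this assay, at which 3 of the 3 values shown sit.

The compounds shown leave open whether any group at this place on the shared core would give a measurable number in this assay, and how far apart these three compounds truly lie.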